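This account rests on a few compounds, and the source may have more. Where it says the series, first, only, none or still open, it means among the compounds named here.

Compound 1, `CC(=O)Nc1cc(C)c(CCS(=O)(=O)N2CCC3(CC2)N=C(C2CCCCC2)NC3=O)c(C)c1`, gives 39 uL/min in an ADME assay on microsomes from liver (Homo sapiens) for metabolic stability, read by LC-MS, using NADPH, with a stated time of 30 min, tested at 1 uM; a higher number here means faster removal of the compound, a lower number slower removal.
Compound 2, `Cc1cc(N(C)C(N)=O)cc(C)c1CCS(=O)(=O)N1CCC2(CC1)N=C(C1CCCCC1)NC2=O`, gives 23 uL/min.
Compound 3, `Cc1cc(N2CCNC2=O)cc(C)c1CCS(=O)(=O)N1CCC2(CC1)N=C(C1CCCCC1)NC2=O`, gives 62 uL/min.

Among these three, compound 2 has the lowest number. Its distance from compound 1 is a 1.7-fold lower number from compound 1 to compound 2 (0.23 log units; within the scatter), so these two cannot be told apart with confidence, whereas the step of a 2.7-fold higher number from compound 2 to compound 3 (0.43 log units; beyond the scatter) does stand clear of the usual spread of repeat measurements. All three measured compounds share one core and differ only in the group attached to an aromatic carbon.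

Compound 4, `Cc1cc(N(C)C(N)=O)cc(C)c1CCS(=O)(=O)N1CCC2(CC1)N=C([C@H]1CC[C@H](C)CC1)NC2=O`, is the next compound to be measured in this assay. It is built from compound 2, and the change is methyl in place of hydrogen on a saturated ring carbon. This alteration sits on the saturated six-membered carbon ring at the other end of the molecule, a part that is identical in compounds 1, 2 and 3. For the measured compounds named here, none of the measured steps therefore bears on it; each of them involves the aromatic substituent and leaves this ring untouched, so there is no measured precedent on which to lean.

Going by the values given here, with no relevant step to draw on, the expectation for compound 4 is a number that does not move beyond the scatter from compound 2, an expected step of a 1.2-fold higher number from compound 2 to compound 4 (0.09 log units; within the scatter). Compound 4 is thus estimated at 28 uL/min, within a range from 14 uL/min to 56 uL/min.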

Compound 4, intrinsic clearance in a liver preparation (reported as CLH), per the amount of preparation that the assay uses: 45 uL/min
Estimate against measurement, compound 4: 1.6-fold (0.21 log units) below; the measured number falls inside the stated range.
By their numbers in this assay, from the lowest: compounds 2, 1, 4 and 3 (each within the scatter of the next, the first and the last beyond it).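

The saturated six-membered carbon ring now has its first measured change: going from cyclohexyl to 4-methylcyclohexyl in this assay gives a 2.0-fold higher number from compound 2 to compound 4 (0.29 log units; within the scatter). One methyl in place of hydrogen, three ring bonds from the ring atom that bears a large group, therefore cannot be told apart from hydrogen with confidence, whereas swapping the aromatic group gives a 2.7-fold higher number from compound 2 to compound 3 (0.43 log units; beyond the scatter), which stands clear of the usual spread of repeat measurements. Nothing given here offers a measured reason for the reading at this ring.

A single pair at one ring position cannot show whether the reading reflects a small real shift or only the scatter of repeated measurements, and it says nothing about how the other aromatic groups, such as the acetamido of compound 1 or the 2-oxoimidazolidin-1-yl of compound 3, would behave alongside the same methyl. Other groups at this ring carbon, such as a hydroxyl, an amine, a carboxylic acid or a longer chain like ethyl, remain open, as does the other spatial arrangement of the methyl on the ring.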